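The source may hold more compounds than are shown below. What is called first, only, known or untested is meant among the compounds shown, and "the series" means these compounds.

The measured compounds:
Compound 1, `O=C(O)c1cc(-c2cocn2)ccc1O`: 110 mg/kg
Compound 2, `O=C(O)c1cc(-c2cccs2)ccc1O`: 60 mg/kg
Compound 3, `O=C(O)c1cc(-c2ccccn2)ccc1O`: 200 mg/kg

All three were tested in a functional assay on the whole organism for inhibition, with Rattus norvegicus as the target, read by paw edema; a lower number here means that less compound is needed, a higher number that more compound is needed for the effect. Compound 2 has the lowest of the three numbers. Its nearest neighbour is compound 1, and the step of a 1.8-fold lower number from compound 1 to compound 2 (0.26 log units; within the scatter) lies within the scatter, so the two cannot be told apart with confidence. Compound 3, which gives 200 mg/kg, stands beyond the scatter from compound 2.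

Compound 4, `O=C(O)c1cc(-n2ccnn2)ccc1O`, has not been measured. It differs from compound 2 in one place:
1H-1,2,3-triazol-1-yl in place of thiophen-2-yl on an aromatic carbon
Within the data shown here, only one measured step bears on an exchange of one five-membered ring for another at this position, and that is a 1.8-fold lower number from compound 1 to compound 2 (0.26 log units; within the scatter), a small one. The ring entering in compound 4 carries more hetero atoms than either the ring leaving or the ring of compound 1, and a ring richer in hetero atoms went with a somewhat higher number in compound 1. That is no firm rule, since compound 3, whose ring has a single hetero atom, gave the highest number of all. A modest rise from compound 2 is therefore expected, most likely within the scatter. The estimate for compound 4 in this assay is 110 mg/kg, with a range from 45 mg/kg to 280 mg/kg. This estimate corresponds to an expected step of a 1.8-fold higher number from compound 2 to compound 4 (0.26 log units; within the scatter).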

Compound 4, dose for half-maximal effect: 150 mg/kg
Estimate against measurement, compound 4: 1.4-fold (0.13 log units) below, and the stated range covers the measured number.
By their numbers in this assay, from the lowest: compounds 2, 1, 4 and 3 (each within the scatter of the next, the first and the last beyond it).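

In this assay, among these compounds, putting 1H-1,2,3-triazol-1-yl in place of thiophen-2-yl gives a 2.5-fold higher number from compound 2 to compound 4 (0.40 log units; beyond the scatter) and so becomes the first exchange of one five-membered aromatic ring for another at this position that lies beyond the scatter. Both rings have the same number of heavy atoms, so a change in the atoms that make up the ring, with its size kept, is enough to move the number here, though only modestly. The exchange of 1,3-oxazol-4-yl for the same triazole gives a 1.4-fold higher number from compound 1 to compound 4 (0.13 log units; within the scatter) and stays within the scatter, so these two rings cannot be told apart, and the thiophene ring is set apart from the triazole ring alone.

On these data alone, it remains open whether the number follows the count of hetero atoms in the ring or the change to a ring attached through nitrogen, and how an open-chain group such as an amine or a longer alkyl chain, or a methyl group on the triazole ring, would behave at this position. Nothing measured for these compounds explains the step.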